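Amide swap from compound 3 to compound 4

The compounds below may be only part of what the source reports. "The series", "measured", "known", "first", "only" and "open" are said of these compounds alone.

Measured in a functional assay on PC-3 cells (Homo sapiens) for inhibition, read by sulforhodamine B assay, with a stated time of 72 h; on this read-out higher numbers stand for weaker inhibition and lower numbers for stronger inhibition:
- compound 1 `Nc1sc(-c2ccc(Cl)cc2)c(-c2ccc(Cl)cc2)c1C(=O)N1CCCCC1`: 14300 nM
- compound 2 `Nc1sc(-c2ccc(Cl)cc2)c(-c2ccc(Cl)cc2)c1C(=O)NC1CCC1`: 24800 nM
- compound 3 `CC(C)(C)NC(=O)c1c(N)sc(-c2ccc(Cl)cc2)c1-c1ccc(Cl)cc1`: 15100 nM

Compound 3 stands within the scatter of both compound 1 and compound 2, so the three values cannot be ranked. The next compound to be read is compound 4 `CN1CCN(C(=O)c2c(N)sc(-c3ccc(Cl)cc3)c2-c2ccc(Cl)cc2)CC1`. The change is 4-methylpiperazin-1-yl in place of (tert-butyl)amino on a carbonyl carbon.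

All three measured steps bear on this position, and all are small: a 1.7-fold higher number from compound 1 to compound 2 (0.24 log units; within the scatter), a 1.6-fold lower number from compound 2 to compound 3 (0.22 log units; within the scatter) and a 1.1-fold higher number from compound 1 to compound 3 (0.02 log units; within the scatter). The last is the most relevant, since piperidin-1-yl in compound 1 is the measured group that most resembles 4-methylpiperazin-1-yl. Resting on compound 1 and its step of a 1.1-fold higher number from compound 1 to compound 3 (0.02 log units; within the scatter), no shift beyond the scatter is expected in this assay. Among the measured compounds shown here, this expectation is weak: no measured compound carries 4-methylpiperazin-1-yl, and three compounds give little coverage, so the range is kept wide.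

The expected outcome is a 1.0-fold lower number from compound 3 to compound 4 (0.00 log units; within the scatter). For compound 4 the estimated value is 15000 nM, with an expected range of 6000 nM to 40000 nM.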

Compound 4, half-maximal inhibitory concentration: 13100 nM
Compound 4: middle estimate off by 1.1-fold (0.06 log units), on the high side; the measured number falls inside the stated range.
By their numbers in this assay, from the lowest: compounds 4, 1, 3 and 2 (each within the scatter of the next).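

In this assay, 4-methylpiperazin-1-yl on the carbonyl carbon leaves the number within the scatter of every earlier amide (a 1.2-fold lower number from compound 3 to compound 4 (0.06 log units; within the scatter); a 1.1-fold lower number from compound 1 to compound 4 (0.04 log units; within the scatter); a 1.9-fold lower number from compound 2 to compound 4 (0.28 log units; within the scatter)), and the widest of these gaps still does not pass the scatter. Among the compounds shown here, the earlier compounds covered only piperidin-1-yl, cyclobutylamino and (tert-butyl)amino, so this is the first sign that a ring with 2 hetero atoms, a second nitrogen and a larger group of 7 heavy atoms are all accepted on this carbonyl carbon without a readable shift, and across the four compounds none goes against that flat picture. No measured evidence available here accounts for this flatness.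

As far as these compounds go, whether any group on this carbonyl carbon can move the number beyond the scatter remains open, for instance a carboxylic acid, a longer chain ending in a primary amine, or an aromatic ring on the amide nitrogen. Also open, from the compounds shown here alone, is whether the shared core sets the level seen in all four compounds, which a change such as fluorine in place of chlorine on that core would begin to test.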